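The source may report more compounds than this note shows. Statements on the series, on what has been measured and on what is new or still open speak of the compounds shown alone.

In a functional assay on NCI-H460 cells (Homo sapiens) for inhibition, read by MTT assay, with a stated time of 72 h (a lower number here means a stronger inhibitor, a higher number a weaker inhibitor), compound 1 `COc1cc(NC(C)CCCNC(=O)Nc2ccc(Br)cc2)c2ncccc2c1` gives 30000 nM and compound 3 `COc1cc(NC(C)CCCNC(=O)NNC(=O)Nc2ccc(C(F)(F)F)cc2)c2ncccc2c1` gives 12000 nM. Compound 2 `COc1cc(NC(C)CCCNC(=O)NNC(=O)Nc2ccc(F)cc2)c2ncccc2c1` has no number, only a limit of the assay: > 100000 nM. Compound 4 `COc1cc(NC(C)CCCNC(=O)NNC(=O)Nc2ccc(Br)cc2)c2ncccc2c1` departs from compound 2 by bromo in place of fluoro on an aromatic carbon. The closest measured step is an at least 8.3-fold lower number from compound 2 to compound 3 (0.92 log units; beyond the scatter), which exchanges the same fluoro for trifluoromethyl. The other step, an at least 3.3-fold higher number from compound 1 to compound 2 (0.52 log units; beyond the scatter), brings in ((4-fluorophenyl)carbamoyl)amino in place of 4-bromophenyl, so it mixes two changes. In both, the fluoro compound carries the higher number. A similar step toward a lower number is therefore expected in this assay: an at least 5.0-fold lower number from compound 2 to compound 4 (0.69 log units; beyond the scatter). For compound 4 the estimated value is 20000 nM, with an expected range of 7000 nM to 70000 nM.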

Compound 4, half-maximal inhibitory concentration: 27000 nM
Beside the measured number, compound 4's estimate is 1.4-fold (0.13 log units) below it; measured number inside the range.
By their numbers in this assay, from the lowest: compound 3; then compounds 4 and 1 (each within the scatter of the next). At a limit, above all of these: compound 2.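

In this assay, bromo on this aromatic carbon, para to a large group, gives a measurable number where fluoro gave only a limit, with an at least 3.7-fold lower number from compound 2 to compound 4 (0.56 log units; beyond the scatter), but it does not reach trifluoromethyl, with a 2.3-fold higher number from compound 3 to compound 4 (0.35 log units; beyond the scatter). With bromo in place, the longer ((4-bromophenyl)carbamoyl)amino link and the plain 4-bromophenyl urea stand level, with a 1.1-fold lower number from compound 1 to compound 4 (0.05 log units; within the scatter). Compound 2 has only a limit of the assay, so the full size of the fluoro to bromo step stays open: the limit of > 100000 nM in this assay, at which 1 of the 4 values shown sits.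

The compounds shown leave open how chloro, methoxy or a nitrile would read at this place, and how a shorter chain on the shared core would read.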